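Second Hydroxy on the Compound 1 Amide: Expected Potency

The compounds below may be only part of what the source reports. "The series", "measured", "known", "first", "only" and "open" are said of these compounds alone.

Compound 1 `O=C(Nc1nc2ccccc2s1)c1ccc(O)cc1` was tested in an assay on isolated protein for inhibition of DNA topoisomerase 1 (Homo sapiens) (on this read-out lower numbers stand for stronger inhibition and higher numbers for weaker inhibition), and compound 1 returns only a limit of the assay, > 100000 nM. Compound 2 `CC(=O)Oc1ccc(C(=O)Nc2ccc(NC(=O)c3ccc(OC(C)=O)c(OC(C)=O)c3)cc2)cc1OC(C)=O` in this assay likewise returns a limit, > 100000 nM. Among the measured compounds shown here, compound 3 `O=C(NC1=NCCS1)c1cc(O)c(O)c(O)c1` in this assay gives 34400 nM, the single numeric value in the set. Compound 1 therefore stands at the limit itself, which is the limit of > 100000 nM in this assay, at which 2 of the 3 values shown sit.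

Compound 4 `O=C(Nc1nc2ccccc2s1)c1ccc(O)c(O)c1` differs from compound 1 by hydroxy in place of hydrogen on an aromatic carbon. For the measured compounds named here, no measured step of this kind exists among the three compounds; the numeric anchor is compound 3 with its three hydroxy groups at 34400 nM. A step toward stronger inhibition beyond the scatter is expected, an at least 1.4-fold lower number from compound 1 to compound 4 (0.15 log units; that floor lies within the scatter), though a reported limit stays quite possible. Compound 4 is estimated at 70000 nM, ranging from 20000 nM to 300000 nM.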

Compound 4, half-maximal inhibitory concentration: 16900 nM
Compound 4: the middle estimate sits 4.1-fold (0.62 log units) above what was measured, and the stated range ends above it.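

Hydroxy in place of hydrogen on an aromatic carbon, ortho to a hydroxy group, gives an at least 5.9-fold lower number from compound 1 to compound 4 (0.77 log units; beyond the scatter) in this assay. The earlier compounds shown here held no step at this position, and compound 4 now gives the core of compound 1 a numeric value. The value of compound 1 is a limit, so the step is a floor only: the limit of > 100000 nM in this assay, at which 2 of the 4 values shown sit.

The compounds shown leave open how large the step really is, and whether it needs hydroxy itself. A methoxy group or an amine at this place would address the second question.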